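Swapping the piperidine for anilines on a quinazoline core

The compounds below may be only part of what the source reports. "The series", "measured", "known", "first", "only" and "open" are said of these compounds alone.

Measured so far:
compound 1, `FC(F)(F)c1ccc(CSc2nc(N3CCCCC3)c3ccccc3n2)cc1`, 25500 nM
compound 2, `Fc1ccc(Nc2nc(SCc3ccc(C(F)(F)F)cc3)nc3ccccc23)cc1`, 7070 nM

Of the compounds shown here, two have been tested in a functional assay on PC-3 cells (Homo sapiens) for cytotoxicity, read by MTT assay, with a stated time of 72 h; on this read-out lower numbers stand for stronger inhibition and higher numbers for weaker inhibition. Compound 1 gives 25500 nM, the highest of the two numbers; its nearest neighbour is compound 2 with 7070 nM. Among the measured compounds shown here, the only measured step replaces piperidin-1-yl with (4-fluorophenyl)amino on an aromatic carbon of the shared core and yields a 3.6-fold lower number from compound 1 to compound 2 (0.56 log units; beyond the scatter).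

Compound 3, `CCOc1ccc(Nc2nc(SCc3ccc(C(F)(F)F)cc3)nc3ccccc23)cc1`, has not yet been measured. It differs from compound 1 in one place: (4-ethoxyphenyl)amino in place of piperidin-1-yl on an aromatic carbon. The change thus again puts an arylamino group where the piperidin-1-yl of compound 1 sat, differing from compound 2 only in the ethoxy on the aromatic ring instead of fluorine. The step from compound 1 to compound 2 bears directly on it and was modest but beyond the scatter. Compound 3 is therefore expected to show a step of about the same size and direction, a 3.6-fold lower number from compound 1 to compound 3 (0.56 log units; beyond the scatter), with a lower number than compound 1. The estimate for compound 3 in this assay is 7000 nM, within a range from 2500 nM to 20000 nM.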

Compound 3, half-maximal inhibitory concentration: 32100 nM
The estimate for compound 3 lay 4.6-fold (0.66 log units) below the measured number; measured number outside the range, above it.
By their numbers in this assay, from the lowest: compound 2; then compounds 1 and 3 (each within the scatter of the next).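

In this assay, putting an arylamino group in place of piperidin-1-yl is not enough on its own to bring the number down, since (4-ethoxyphenyl)amino on the same aromatic carbon gives a 1.3-fold higher number from compound 1 to compound 3 (0.10 log units; within the scatter) and so does not separate compound 3 from compound 1. What separates the two arylamino compounds is the group on their aromatic ring, where ethoxy in place of fluoro gives a 4.5-fold higher number from compound 2 to compound 3 (0.66 log units; beyond the scatter), so the gain seen with compound 2 depends on that group and does not carry over to every arylamino group at this place. No measurement is at hand that accounts for the difference between fluoro and ethoxy here.

The three compounds leave open whether the lower number of compound 2 is particular to fluoro, or whether a plain phenylamino group, a chloro or a methoxy on the same ring would give a similar number. They also leave open whether a shorter amine such as a morpholine or a dimethylamino group at this place would differ from piperidin-1-yl at all.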